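The source may hold more compounds than are shown below. What is called first, only, known or untested is meant among the compounds shown, and "the series" means these compounds.

In a functional assay on THP-1 cells (Homo sapiens) for inhibition, read by sulforhodamine B assay, with a stated time of 48 h, tested at 50 uM (on this read-out higher numbers stand for more inhibition of growth at the one concentration tested and lower numbers for less inhibition of growth), compound 1 (`COc1ccc(/C=C/C(=O)/C=C/c2ccc(OCc3cn(CCCCOc4cc(=O)oc5ccccc45)nn3)c(OC)c2)cc1OC`) gives 59%, compound 2 (`COc1cc(/C=C/C(=O)/C=C/c2ccccc2)ccc1OCc1cn(CCCCOc2cc(=O)oc3ccccc23)nn1`) gives 36% and compound 3 (`COc1cc(/C=C/C(=O)/C=C/c2cccc3ccccc23)ccc1OCc1cn(CCCCOc2cc(=O)oc3ccccc23)nn1`) gives 54%. Two steps place compound 3 in the upper pair of the three: a number 5 percentage points lower from compound 1 to compound 3 (within the scatter), and a number 18 percentage points higher from compound 2 to compound 3 (beyond the scatter). Next is compound 4 (`COc1ccccc1/C=C/C(=O)/C=C/c1ccc(OCc2cn(CCCCOc3cc(=O)oc4ccccc34)nn2)c(OC)c1`), with 2-methoxyphenyl in place of naphthalen-1-yl on a double-bonded chain carbon bound to a double-bonded chain carbon. Going by the values given here, the largest change at this place so far is a number 23 percentage points lower from compound 1 to compound 2 (beyond the scatter). The entering group has not been measured in this series, but it is expected to fall within the span set by phenyl in compound 2 and 3,4-dimethoxyphenyl in compound 1. No change beyond the scatter is expected in this assay: the expected step is a number 5 percentage points lower from compound 3 to compound 4 (within the scatter). For compound 4 the estimated value is 49%, with an expected range of 37% to 61%.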

Compound 4, percent growth inhibition at one concentration: 40%
For compound 4 the middle estimate is 9 percentage points above the measured one; the range from low to high includes it.
By their numbers in this assay, from the lowest: compounds 2 and 4 (each within the scatter of the next); then compounds 3 and 1 (each within the scatter of the next).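

In this assay one methoxy on the phenyl ring does not separate the two compounds, with a number 4 percentage points higher from compound 2 to compound 4 (within the scatter) on record, so this single group does not reproduce the level of compound 1. The 3,4-dimethoxyphenyl group stands apart, with a number 19 percentage points lower from compound 1 to compound 4 (beyond the scatter) as the step, and naphthalen-1-yl does too, with a number 14 percentage points lower from compound 3 to compound 4 (beyond the scatter) as the step, so compounds 1 and 3 now form an upper pair over compounds 2 and 4. No supporting data explain these steps. On these data alone, how an amine or a carboxylic acid on this aromatic ring would read remains open, as does the effect of a longer chain in the core.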